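The compounds below may be only part of what the source reports. "The series", "measured", "known", "first", "only" and "open" are said of these compounds alone.

Measured so far in an in vitro ADME assay on microsomes from liver (Homo sapiens) for metabolic stability, read by LC-MS; a lower number here means that the compound disappears faster, a higher number that the compound lasts longer:
compound 1 `CCCCc1ccc(NC(=O)N2CCCN(C(=O)CCC3CCCC3)CC2)cc1`, 0.0833 h
compound 2 `CC(C)(C)c1ccc(NC(=O)N2CCCN(C(=O)CC3CCCC3)CC2)cc1`, 0.05 h
compound 3 `CC(C)CCC(=O)N1CCCN(C(=O)Nc2ccc(C(C)(C)C)cc2)CC1`, 0.05 h

Compound 3 stands level with compound 2 at the digits shown, and compound 1 differs from it only within the scatter; all three numbers therefore sit close together, and compound 3 gives no sign of standing apart in this assay.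

Compound 4 `CC(C)(C)c1ccc(NC(=O)N2CCCN(C(=O)C3CCOCC3)CC2)cc1` is the next one to be measured. It differs from compound 3 in one place: oxan-4-yl in place of isopentyl on a carbonyl carbon.

For the measured compounds named here, only one measured step touches this position: no change at the digits printed from compound 2 to compound 3 (within the scatter). That exchange of one saturated side chain for another on the same carbonyl carbon left the half-life unchanged within the scatter. Going by the values given here, no measured pair involves a ring with a hetero atom at this place, so the oxan-4-yl group has no direct precedent. On the evidence of that single step, the expectation for compound 4 in this assay is a 1.4-fold higher number from compound 3 to compound 4 (0.15 log units; within the scatter), that is, no movement beyond the scatter. Compound 4 is therefore estimated at 0.07 h, with a range from 0.035 h to 0.15 h.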

Compound 4, half-life: 0.183 h
For compound 4 the middle estimate is 2.6-fold (0.42 log units) below the measured one, outside the stated range (above it).
By their numbers in this assay, from the lowest: compounds 2, 3 and 1 (each within the scatter of the next); then compound 4.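

In this assay oxan-4-yl in place of isopentyl gives a 3.7-fold higher number from compound 3 to compound 4 (0.56 log units; beyond the scatter) and oxan-4-yl in place of cyclopentylmethyl gives a 3.7-fold higher number from compound 2 to compound 4 (0.56 log units; beyond the scatter) so the side chain on this carbonyl carbon can shift the half-life, which the exchange between the two all-carbon chains, with no change at the digits printed from compound 2 to compound 3 (within the scatter) as its result, did not reveal. The entering group brings a six-membered non-aromatic ring with one hetero atom and one hydrogen-bond acceptor, but this single compound cannot separate the ring oxygen from the ring itself. No measurement at hand accounts for the rise.

Open, from the compounds shown here alone, is whether cyclohexyl on the same carbonyl carbon would match oxan-4-yl, which would test the ring oxygen directly. Also open, going by these compounds, is whether a piperidin-4-yl amine there, or oxan-4-yl paired with the butyl group of compound 1, would give a similar rise.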